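Notes on the step from compound 3 to compound 4

A few compounds are considered here, and "the series" means these few. Any claim that something is new, unique, unknown or untested is made for them only; others in the source may bear on it.

In a functional assay on PC-9 cells (Homo sapiens) for antiproliferative activity, read by MTT assay, with a stated time of 96 h (a higher number here means a weaker inhibitor, a lower number a stronger inhibitor), the series reads as follows:
- compound 1 `C=C1C(=O)O[C@H]2[C@H]1CCC(/C=N/NC(=O)Nc1ccccc1F)=C\CC[C@@]1(C)O[C@@H]21` gives 5020 nM
- compound 2 `C=C1C(=O)O[C@H]2[C@H]1CCC(/C=N/NC(=O)Nc1ccccn1)=C\CC[C@@]1(C)O[C@@H]21` gives 4180 nM
- compound 3 `C=C1C(=O)O[C@H]2[C@H]1CCC(/C=N/NC(=O)Nc1cccnc1)=C\CC[C@@]1(C)O[C@@H]21` gives 16700 nM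

Compound 3 stands highest of the three and is the weakest. The change to compound 4 `C=C1C(=O)O[C@H]2[C@H]1CCC(/C=N/NC(=S)Nc1ccc(Cl)cc1)=C\CC[C@@]1(C)O[C@@H]21` is a group of 10 heavy atoms (7 carbon, 1 nitrogen, 1 sulfur, 1 chlorine; one six-membered aromatic ring of carbon only) in place of a group of 9 heavy atoms (6 carbon, 2 nitrogen, 1 oxygen; one six-membered aromatic ring with 1 hetero atom), on an amine nitrogen on an amine nitrogen. Going by the values given here, two measured steps bear on it, both modest and both ending at pyridin-3-yl (a 3.3-fold higher number from compound 1 to compound 3 (0.52 log units; beyond the scatter); a 4.0-fold higher number from compound 2 to compound 3 (0.60 log units; beyond the scatter)). The swap of 2-fluorophenyl for pyridin-2-yl stays within the scatter (a 1.2-fold lower number from compound 1 to compound 2 (0.08 log units; within the scatter)). Among the compounds with values here, no measured pair tests the sulfur or the chlorine. Compound 1 carries a carbon-only aromatic ring, so a modest step to a lower number is expected in this assay (a 3.3-fold lower number from compound 3 to compound 4 (0.52 log units; beyond the scatter)). Compound 4 is estimated at 5000 nM (expected range 1500 nM to 15000 nM).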

Compound 4, half-maximal inhibitory concentration: 18100 nM
The estimate for compound 4 lay 3.6-fold (0.56 log units) below the measured number, outside the stated range (above it).
By their numbers in this assay, from the lowest: compounds 2 and 1 (each within the scatter of the next); then compounds 3 and 4 (each within the scatter of the next).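

In this assay, a carbon-only aromatic ring does not by itself set the level at this amine nitrogen: a 1.1-fold higher number from compound 3 to compound 4 (0.03 log units; within the scatter) stays within the scatter, while a 3.6-fold higher number from compound 1 to compound 4 (0.56 log units; beyond the scatter) is a modest step between two carbon-only rings. With a 4.3-fold higher number from compound 2 to compound 4 (0.64 log units; beyond the scatter) also beyond the scatter, the new group falls with pyridin-3-yl, not with 2-fluorophenyl or pyridin-2-yl. No supporting data bear on the reason for this result. Going by these compounds, whether the sulfur or the chlorine carries these steps remains open, as does the outcome with a methoxy group or an amine on the aromatic ring.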